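One added oxygen on the cyano-bearing ring

This account rests on a few compounds, and the source may have more. Where it says the series, first, only, none or still open, it means among the compounds named here.

In a functional assay (aorta) with Rattus norvegicus as the target, in the presence of a further agent that is not named here (a lower number here means that less compound is needed, a higher number that more compound is needed for the effect), compound 1 (`COC(=O)C1=C(C)N=C(C)/C(=C(/O)OC)C1c1cccc(OCCO[N+](=O)[O-])c1`) gives 750 nM and compound 2 (`COC(=O)C1=C(C)N=C(C)/C(=C(/O)OC)C1c1cccc(OCc2nonc2C)c1`) gives 640 nM while compound 3 (`COC(=O)C1=C(C)N=C(C)/C(=C(/O)OC)C1c1cccc(OCc2nonc2C#N)c1`) stands lowest of the three with 310 nM as its number. Compound 4 (`COC(=O)C1=C(C)N=C(C)/C(=C(/O)OC)C1c1cccc(OCc2no[n+]([O-])c2C#N)c1`) departs from compound 3 through one change, a group of 8 heavy atoms (3 carbon, 3 nitrogen, 2 oxygen; one five-membered aromatic ring with 3 hetero atoms) in place of a group of 7 heavy atoms (3 carbon, 3 nitrogen, 1 oxygen; one five-membered aromatic ring with 3 hetero atoms), on a saturated chain carbon bound to an oxygen on an aromatic ring and nothing else. Within the data shown here, no measured step makes this same change. The closest guides are a 2.1-fold lower number from compound 2 to compound 3 (0.31 log units; beyond the scatter) and a 2.4-fold lower number from compound 1 to compound 3 (0.38 log units; beyond the scatter) as two modest steps, while a 1.2-fold lower number from compound 1 to compound 2 (0.07 log units; within the scatter) stays within the scatter. Only a modest move toward lower numbers is therefore expected, with a 2.1-fold lower number from compound 3 to compound 4 (0.32 log units; beyond the scatter) as the estimated step, though its direction remains uncertain. For compound 4 the estimated value is 150 nM within an expected range from 30 nM to 500 nM on this evidence.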

Compound 4, half-maximal effective concentration: 3.3 nM
For compound 4 the middle estimate is 45-fold (1.66 log units) above the measured one; measured number below the stated range.
By their numbers in this assay, from the lowest: compound 4; then compound 3; then compounds 2 and 1 (each within the scatter of the next).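

At this position, on a saturated chain carbon bound to an oxygen on an aromatic ring, a single added oxygen on the ring outweighs every earlier change: in this assay it gives a 94-fold lower number from compound 3 to compound 4 (1.97 log units; beyond the scatter) and so exceeds the modest earlier steps. The new ring also stands far from the other two groups, with a 190-fold lower number from compound 2 to compound 4 (2.29 log units; beyond the scatter) and a 230-fold lower number from compound 1 to compound 4 (2.36 log units; beyond the scatter) as the larger gaps. Nothing available explains why this oxygen matters so much. As far as these compounds go, whether the added oxygen works equally well with a methyl or a carboxamide in place of the cyano remains open, and so does the effect of a longer chain leading to the ring.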